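Pyridinyl replaces a fused bicyclic amide on the triazole nitrogen

This account rests on a few compounds, and the source may have more. Where it says the series, first, only, none or still open, it means among the compounds named here.

Measured compounds:
compound 1 `COC1=C(C)C(=O)C(CCCCCCCCCCn2cc(C[C@H](O)COCCOC[C@@H](O)Cc3ccc(-c4ccccc4)cc3)nn2)=C(C)C1=O` with 505 nM
compound 2 `O=C1COc2ccc(-n3cc(C[C@H](O)COCCOC[C@@H](O)Cc4ccc(-c5ccccc5)cc4)nn3)cc2N1` with 15200 nM
compound 3 `COC1=C(OC)C(=O)C(CCCCCCn2cc(C[C@H](O)COCCOC[C@@H](O)Cc3ccc(-c4ccccc4)cc3)nn2)=C(C)C1=O` with 16700 nM

In a functional assay on SGC-7901 cells (Homo sapiens) for inhibition, read by MTT assay, with a stated time of 72 h (on this read-out higher numbers stand for weaker inhibition of growth and lower numbers for stronger inhibition of growth), compound 2 gives 15200 nM and stands at the second highest of the three numbers. Compound 3 gives 16700 nM, which lies within the scatter of compound 2, so no order can be drawn between them. Compound 1 gives 505 nM, a number beyond the scatter below compound 2.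

Compound 4 `O[C@H](COCCOC[C@@H](O)Cc1cn(-c2cccnc2)nn1)Cc1ccc(-c2ccccc2)cc1` is not yet measured. It differs from compound 2 by a group of 6 heavy atoms (5 carbon, 1 nitrogen; one six-membered aromatic ring with 1 hetero atom) in place of a group of 11 heavy atoms (8 carbon, 1 nitrogen, 2 oxygen; one six-membered non-aromatic ring with 2 hetero atoms, one six-membered aromatic ring of carbon only), on an aromatic nitrogen. For the measured compounds named here, no measured pair shows a change of this kind, so the expectation rests on compound 2 alone. The step of a 1.2-fold higher number from compound 2 to compound 4 (0.07 log units; within the scatter) is expected to stay within the scatter, with no clear direction. Compound 4 is estimated at 18000 nM, with a range from 6000 nM to 55000 nM.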

Compound 4, concentration for 50% growth inhibition: 29800 nM
Compound 4: the middle estimate sits 1.7-fold (0.22 log units) below what was measured, within the range that was stated.
By their numbers in this assay, from the lowest: compound 1; then compounds 2, 3 and 4 (each within the scatter of the next).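

At this position, on an aromatic nitrogen of the five-membered ring, the large fused group can give way to the much smaller pyridin-3-yl with no clear effect in this assay, giving a 2.0-fold higher number from compound 2 to compound 4 (0.29 log units; within the scatter). The group that leaves has 1 hydrogen-bond donor and pyridin-3-yl has 0, yet the two numbers cannot be told apart. Nothing available explains this result.

As far as these compounds go, whether an amine or a carboxylic acid on the pyridin-3-yl ring would shift the number remains open. So does the effect of a longer chain between that ring and the aromatic nitrogen.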